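Swapping a Sulfonyl for a Carbonyl on the Ring Nitrogen

The compounds below may be only part of what the source reports. "The series", "measured", "known", "first", "only" and "open" are said of these compounds alone.

Compound 3 `COc1ccc(S(=O)(=O)N2CCc3cccc(NS(=O)(=O)c4ccccc4)c32)cc1` gives 562 nM in a functional assay on MKN-45 cells (Homo sapiens) for cytotoxicity (on this read-out higher numbers stand for weaker inhibition and lower numbers for stronger inhibition), the highest of the three numbers recorded. Compound 2 `COc1ccc(S(=O)(=O)N2CCc3cccc(NC(=O)c4ccncc4)c32)cc1` gives 8.8 nM, and compound 1 `COc1ccc(S(=O)(=O)N2CCc3cccc(NC(=O)c4ccc([N+](=O)[O-])cc4)c32)cc1` gives 95 nM. Two steps are on record: an 11-fold lower number from compound 1 to compound 2 (1.03 log units; beyond the scatter) and a 64-fold higher number from compound 2 to compound 3 (1.81 log units; beyond the scatter), both large. Compound 4 `COc1ccc(S(=O)(=O)N2CCc3cccc(NC(=O)N(C)c4ccccc4)c32)cc1` differs from compound 3 in that (methyl(phenyl)carbamoyl in place of phenylsulfonyl on a nitrogen on an aromatic ring). This restores a carbonyl on that nitrogen, as in compounds 1 and 2, though the group beyond it matches neither. The step of a 64-fold higher number from compound 2 to compound 3 (1.81 log units; beyond the scatter) bears most directly on this change, so a lower number is expected, but not the full return seen there. Compound 4 is therefore estimated at 100 nM (range 20 nM to 600 nM), a step of a 5.6-fold lower number from compound 3 to compound 4 (0.75 log units; beyond the scatter).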

Compound 4, half-maximal inhibitory concentration: > 10000 nM
Compound 4: a limit, no number (the forecaster's own chance of this, stated with the estimate: 5%); middle value at least 100-fold (2.00 log units) away from the limit.
By their numbers in this assay, from the lowest: compound 2; then compound 1; then compound 3. At a limit, above all of these: compound 4.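

Compound 4 stands as a limit and not as a number in this assay: the limit of > 10000 nM in this assay, at which 1 of the 4 values shown sits. A carbonyl on the nitrogen on an aromatic ring is therefore not enough on its own, since methyl(phenyl)amino on the carbonyl carbon falls far behind both pyridin-4-yl (an at least 1100-fold higher number from compound 2 to compound 4 (3.05 log units; beyond the scatter)) and 4-nitrophenyl (an at least 100-fold higher number from compound 1 to compound 4 (2.02 log units; beyond the scatter)). Here the carbonyl compound even falls behind the phenylsulfonyl compound (an at least 17-fold higher number from compound 3 to compound 4 (1.25 log units; beyond the scatter)), so the group beyond the carbonyl matters at least as much as the carbonyl itself.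

As far as these compounds go, whether the loss follows the methyl on the added nitrogen or that nitrogen itself stays open. So does the standing of a plain phenyl or a piperidine on the carbonyl carbon.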